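The compounds below may be only part of what the source reports. "The series", "measured", "known", "first", "only" and "open" are said of these compounds alone.

Measured so far in a functional assay on MCF7 cells (Homo sapiens) for cytotoxicity, read by MTT assay, with a stated time of 72 h; a higher number here means a weaker inhibitor, a lower number a stronger inhibitor:

compound 1, `COc1ccc(-c2ccc(C(=O)Nc3ccc(Oc4ccnc5[nH]ccc45)cc3)nc2)cc1`, which gives > 10000 nM, a limit of the assay
compound 2, `O=C(Nc1ccc(Oc2ccnc3[nH]ccc23)cc1)c1ccc(-c2ccc(F)cc2F)cn1`, which gives > 10000 nM, likewise a limit
compound 3, `COc1ccc(-c2ccc(C(=O)Nc3ccc(Oc4ccnc5[nH]ccc45)c(F)c3)nc2)cc1`, which gives 10100 nM

Compound 3 therefore stands as the only one of the three with a number in this assay; the other two sit at the limit of > 10000 nM in this assay, at which 2 of the 3 values shown sit, which is a limit and not a number. Compound 4, `O=C(Nc1ccc(Oc2ccnc3[nH]ccc23)c(F)c1)c1ccc(-c2ccc(F)cc2F)cn1`, is to be measured next. It differs from compound 3 by 2,4-difluorophenyl in place of 4-methoxyphenyl on an aromatic carbon. The same exchange has already been made once, from compound 1 to compound 2, where the result is a step that the two limits leave unreadable from compound 1 to compound 2, because both ends sit at the limit of > 10000 nM in this assay, at which 2 of the 3 values shown sit. The step from compound 1 to compound 3 is a step that the limit leaves unreadable from compound 1 to compound 3. No readable step thus bears on the change in hand, and with compound 3 itself standing almost at the limit, a step no larger than the scatter is expected, in no fixed direction. Compound 4 is accordingly estimated at 10000 nM, between 5000 nM and 20000 nM, which would make the expected step of a 1.0-fold lower number from compound 3 to compound 4 (0.00 log units; within the scatter), with a fair chance that only a limit is reported.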

Compound 4, half-maximal inhibitory concentration: > 10000 nM
Compound 4: a limit, no number; the forecaster's own chance of this, stated with the estimate: 60%; the middle value lies on the limit itself.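

In this assay compound 4 gives > 10000 nM, a limit and not a number. The steps from compound 3 to compound 4 and from compound 2 to compound 4 cannot be read. The compounds shown leave open whether either exchange, 2,4-difluorophenyl for 4-methoxyphenyl or fluoro for hydrogen, moves the value in this assay at all.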